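From 3-methoxyphenyl to 4-fluorophenyl on an aromatic nitrogen

A few compounds are considered here, and "the series" means these few. Any claim that something is new, unique, unknown or untested is made for them only; others in the source may bear on it.

In a functional assay on HeLa cells (Homo sapiens) for antiproliferative activity, read by MTT assay, with a stated time of 72 h (on this read-out lower numbers stand for stronger inhibition and higher numbers for weaker inhibition), compound 1 `COc1cc(-c2nccn2C)cc(OC)c1OC` reaches only a limit, > 100000 nM. Compound 2 `CCCCn1ccnc1-c1cc(OC)c(OC)c(OC)c1` also reaches only a limit, > 100000 nM. Within the data shown here, compound 3 `COc1cccc(-n2ccnc2-c2cc(OC)c(OC)c(OC)c2)c1` gives 11000 nM, the only actual number of the three. Compound 4 `COc1cc(-c2nccn2-c2ccc(F)cc2)cc(OC)c1OC` carries 4-fluorophenyl in place of 3-methoxyphenyl on an aromatic nitrogen. Among the measured compounds shown here, two measured steps bear on this change: an at least 9.0-fold lower number from compound 1 to compound 3 (0.95 log units; beyond the scatter) and an at least 9.0-fold lower number from compound 2 to compound 3 (0.95 log units; beyond the scatter). Both introduce the 3-methoxyphenyl in place of a chain, whereas compound 4 retains one six-membered aromatic ring of carbon only, so no step beyond the scatter is expected in this assay. The expected step is a 1.1-fold lower number from compound 3 to compound 4 (0.04 log units; within the scatter). For compound 4 the estimated value is 10000 nM, with an expected range of 2500 nM to 40000 nM.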

Compound 4, half-maximal inhibitory concentration: 17500 nM
Compound 4: the middle estimate sits 1.8-fold (0.24 log units) below what was measured; the measured number falls inside the stated range.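

In this assay, 4-fluorophenyl on this aromatic nitrogen also outperforms the chains, with an at least 5.7-fold lower number from compound 2 to compound 4 (0.75 log units; beyond the scatter) and an at least 5.7-fold lower number from compound 1 to compound 4 (0.75 log units; beyond the scatter), so the gain is not confined to 3-methoxyphenyl. Exchanging one ring for the other gives a 1.6-fold higher number from compound 3 to compound 4 (0.20 log units; within the scatter), so the two cannot be told apart here, although only 3-methoxyphenyl counts a hydrogen-bond acceptor. The steps from the chains are only bounds because compound 1 and compound 2 stand at a limit: the limit of > 100000 nM in this assay, at which 2 of the 4 values shown sit.

Still open, as far as these compounds go, is whether a phenyl ring bearing an amine or a carboxylic acid would fit this nitrogen equally well. From the compounds shown here alone, the effect of a benzyl group there also remains unknown.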